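The source may hold more compounds than are shown below. What is called first, only, known or untested is meant among the compounds shown, and "the series" means these compounds.

Measured so far:
compound 1 `CC(C)C[C@H](N)C(=O)NS(=O)(=O)OC[C@H]1OC[C@@H](n2cnc3c(N)ncnc32)[C@H](O)[C@@H]1O` — 1000 nM
compound 2 `CSCC[C@H](N)C(=O)NS(=O)(=O)OC[C@H]1OC[C@@H](n2cnc3c(N)ncnc32)C[C@@H]1O` — 5500 nM
compound 3 `C[C@H](N)C(=O)NS(=O)(=O)OC[C@H]1OC[C@@H](n2cnc3c(N)ncnc32)C[C@@H]1O` — 5500 nM

In a functional assay on PBMC cells (Homo sapiens) for inhibition (a higher number here means a weaker inhibitor, a lower number a stronger inhibitor), compound 3 gives 5500 nM, level with compound 2 and together with it the highest number of the three; compound 1 stands furthest off, with a number lower by a margin beyond the scatter. The step of no change at the digits printed from compound 2 to compound 3 (within the scatter) shows that exchanging a (methylsulfanyl)methyl group for hydrogen at that chain carbon left this assay unmoved.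

Compound 4 `CC(C)C[C@H](N)C(=O)NS(=O)(=O)OC[C@H]1OC[C@@H](n2cnc3c(N)ncnc32)C[C@@H]1O` is not yet measured. It differs from compound 3 by isopropyl in place of hydrogen on a saturated chain carbon, two bonds along the chain from an amine nitrogen and a carbonyl carbon. Among the compounds with values here, the one step that bears on this position, no change at the digits printed from compound 2 to compound 3 (within the scatter), was flat, so a group of similar size entering at the same carbon is expected to move this assay little, if at all, beyond the scatter. Compound 1 also carries the isobutyl chain but on a different core and cannot be read as a step to compound 4; its lower number is noted only as what its value shows. For compound 4 the estimate is therefore 4000 nM (range 1500 nM to 12000 nM), a step of a 1.4-fold lower number from compound 3 to compound 4 (0.14 log units; within the scatter) expected to stay within the scatter.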

Compound 4, half-maximal inhibitory concentration: 6800 nM
The estimate for compound 4 lay 1.7-fold (0.23 log units) below the measured number; measured number inside the range.
By their numbers in this assay, from the lowest: compound 1; then compounds 2, 3 and 4 (each within the scatter of the next).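

In this assay, entering isopropyl on the saturated chain carbon gives a 1.2-fold higher number from compound 3 to compound 4 (0.09 log units; within the scatter), and exchanging (methylsulfanyl)methyl for isopropyl gives a 1.2-fold higher number from compound 2 to compound 4 (0.09 log units; within the scatter), so hydrogen and both groups read alike at this position on the shared core. Within the data shown here, the hydroxy on the saturated ring carbon now has its own single-place comparison: with the chain held constant, hydrogen in place of hydroxy gives a 6.8-fold higher number from compound 1 to compound 4 (0.83 log units; beyond the scatter), the only step here beyond the scatter. No measurement is available to explain either reading.

Still open, as far as these compounds go, is whether this chain carbon stays flat with a chain ending in an amine or a carboxylic acid, or with a benzyl group. Among these compounds, it is also open whether the hydroxy step holds with chains other than the one shared by compound 1 and compound 4.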